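Swapping methyl for trifluoromethyl on the amide-bearing ring

A few compounds are considered here, and "the series" means these few. Any claim that something is new, unique, unknown or untested is made for them only; others in the source may bear on it.

Of the compounds shown here, three sharing one core have been measured in a functional assay on HEK293 cells for negative allosteric modulation of metabotropic glutamate receptor 5 (Homo sapiens), read by calcium flux, with a stated time of 20 min; on this read-out higher numbers stand for weaker inhibition and lower numbers for stronger inhibition. Compound 1 `O=C(c1ccccc1)N1CCn2nc(-c3ccc(F)cn3)cc2C1` gives 164 nM. Compound 2 `O=C(c1cccc(F)c1)N1CCn2nc(-c3ccc(F)cn3)cc2C1`, which carries a fluoro in place of a hydrogen on the ring next to the carbonyl, gives 257 nM. Compound 3 `Cc1cccc(C(=O)N2CCn3nc(-c4ccc(F)cn4)cc3C2)c1`, which carries a methyl at that same place, gives 150 nM. The three numbers sit close together: the change from compound 1 to compound 2 is a 1.6-fold higher number from compound 1 to compound 2 (0.20 log units; within the scatter), from compound 1 to compound 3 it is a 1.1-fold lower number from compound 1 to compound 3 (0.04 log units; within the scatter), and from compound 2 to compound 3 it is a 1.7-fold lower number from compound 2 to compound 3 (0.23 log units; within the scatter), so compound 3 cannot be set apart from the others on these numbers.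

Compound 4 `O=C(c1cccc(C(F)(F)F)c1)N1CCn2nc(-c3ccc(F)cn3)cc2C1` is the next step: trifluoromethyl in place of methyl on an aromatic carbon. Going by the values given here, no measured pair contains a trifluoromethyl, so the only guidance is that all three changes tried at this aromatic position stayed within the scatter. On that basis, the step from compound 3 to compound 4 in this assay is expected to be a 1.3-fold higher number from compound 3 to compound 4 (0.12 log units; within the scatter), with no clear direction. Compound 4 is therefore estimated at 200 nM, within a range from 80 nM to 500 nM.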

Compound 4, half-maximal inhibitory concentration: 383 nM
For compound 4 the middle estimate is 1.9-fold (0.28 log units) below the measured one; the range from low to high includes it.
By their numbers in this assay, from the lowest: compounds 3, 1, 2 and 4 (each within the scatter of the next, the first and the last beyond it).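

In this assay, going by these compounds alone, this aromatic carbon proves less indifferent to its substituent than the first three compounds suggested, as trifluoromethyl gives the first steps beyond the scatter: a 2.6-fold higher number from compound 3 to compound 4 (0.41 log units; beyond the scatter) and a 2.3-fold higher number from compound 1 to compound 4 (0.37 log units; beyond the scatter), both modest in size. The change does not separate trifluoromethyl from every other group, however, as a 1.5-fold higher number from compound 2 to compound 4 (0.17 log units; within the scatter) stays within the scatter, so the fluoro and trifluoromethyl compounds cannot be told apart on these numbers, and only the hydrogen and methyl compounds lie clearly on the lower side of compound 4. The data shown offer no independent measurement that could explain this shift, so the four numbers describe what happens at this position but not the reason for it.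

The compounds shown leave open what a methoxy group, a nitrile or an amine would do on this same aromatic carbon, and whether a longer chain such as ethyl would track with methyl or with trifluoromethyl. They also leave open whether swapping methyl for trifluoromethyl gives a step of similar size on another aromatic carbon of this ring.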